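A few compounds are considered here, and "the series" means these few. Any claim that something is new, unique, unknown or untested is made for them only; others in the source may bear on it.

Measured so far in a functional assay on MGC-803 cells (Homo sapiens) for inhibition, read by sulforhodamine B assay; on this read-out lower numbers stand for stronger inhibition and higher numbers for weaker inhibition:
compound 1 `COc1cccc(NC2=CC(=O)c3c(nc4n3[C@H]3OC[C@@H](O)[C@H]3OC4)C2=O)c1`: 1790 nM
compound 3 `O=C1C(Nc2ccccc2)=CC(=O)c2c1nc1n2[C@H]2OC[C@@H](O)[C@H]2OC1`: 1830 nM
compound 2 `O=C1C=C(NC2CCCCC2)C(=O)c2c1nc1n2[C@H]2OC[C@@H](O)[C@H]2OC1`: a limit of the assay, > 8000 nM

Compound 1 has the lowest of the two numbers given; its nearest neighbour is one step away, a 1.0-fold higher number from compound 1 to compound 3 (0.01 log units; within the scatter), within the scatter. Compound 2, with a cyclohexyl on the amine nitrogen, shows only a limit (the limit of > 8000 nM in this assay, at which 1 of the 3 values shown sits). The step now followed leads from compound 1 to compound 4 `O=C1C(Nc2ccc(I)cc2)=CC(=O)c2c1nc1n2[C@H]2OC[C@@H](O)[C@H]2OC1`: 4-iodophenyl in place of 3-methoxyphenyl on an amine nitrogen. Among the measured compounds shown here, the single measured step bearing on this ring, a 1.0-fold higher number from compound 1 to compound 3 (0.01 log units; within the scatter), changed nothing beyond the scatter, so no shift beyond the scatter is expected here either; compound 2 is the only value outside, and it lacks the aromatic ring. Compound 4 is therefore expected at 1600 nM, between 500 nM and 5000 nM, a step estimated as a 1.1-fold lower number from compound 1 to compound 4 (0.05 log units; within the scatter).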

Compound 4, half-maximal inhibitory concentration: 2150 nM
For compound 4 the middle estimate is 1.3-fold (0.13 log units) below the measured one, within the range that was stated.
By their numbers in this assay, from the lowest: compounds 1, 3 and 4 (each within the scatter of the next). At a limit, above all of these: compound 2.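

In this assay, iodo in place of hydrogen gives a 1.2-fold higher number from compound 3 to compound 4 (0.07 log units; within the scatter) and the full exchange of aryl groups gives a 1.2-fold higher number from compound 1 to compound 4 (0.08 log units; within the scatter). Among the compounds shown here, the aromatic ring on the amine nitrogen has now carried hydrogen, 3-methoxy and 4-iodo without a step beyond the scatter, and this is the first substituent at the 4 position of that ring. Nothing measured in this set accounts for this flat response.

Still open, going by these compounds, is whether a carboxylic acid or a dimethylamino group on this ring would move the number beyond the scatter. A benzyl group on the amine nitrogen is equally unresolved.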